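The compounds below may be only part of what the source reports. "The series", "measured", "known", "first", "only" and "open" are said of these compounds alone.

Working notes on the series. Compound 1 `CCCc1c(COc2ccc(-c3nn[nH]n3)cc2)ccc(C(C)=O)c1O` carries a 2H-tetrazol-5-yl group on an aromatic carbon; in a functional assay on ileum (Cavia porcellus) for inhibition of cysteinyl leukotriene receptor (Homo sapiens) (on this read-out higher numbers stand for weaker inhibition and lower numbers for stronger inhibition), compound 1 gives 10 nM. Compound 2 `CCCc1c(COc2ccc(Cc3nnn[nH]3)cc2)ccc(C(C)=O)c1O` carries (1H-tetrazol-5-yl)methyl in its place, and in this assay compound 2 gives 10 nM. The step of no change at the digits printed from compound 1 to compound 2 (within the scatter) shows that exchanging 2H-tetrazol-5-yl for (1H-tetrazol-5-yl)methyl leaves the read-out within the scatter. Compound 2 thus stands level with compound 1 at the digits shown, within the scatter.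

Compound 3 `CCCc1c(COc2ccc(OCc3nn[nH]n3)cc2)ccc(C(C)=O)c1O` is not yet measured. It differs from compound 2 by (2H-tetrazol-5-yl)methoxy in place of (1H-tetrazol-5-yl)methyl on an aromatic carbon, sitting on an aromatic carbon of a six-membered aromatic ring of carbon only, para to a large group. Among the measured compounds shown here, the only measured step that bears on this change is no change at the digits printed from compound 1 to compound 2 (within the scatter), in which the (1H-tetrazol-5-yl)methyl group in place of 2H-tetrazol-5-yl left the read-out within the scatter. For the measured compounds named here, no measured step covers a (2H-tetrazol-5-yl)methoxy group, so the expectation rests on that single step alone. For compound 3 in this assay the expected step is no change at the digits printed from compound 2 to compound 3 (within the scatter), none beyond the scatter. Compound 3 is therefore estimated at 10 nM, within 3 nM to 30 nM.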

Compound 3, half-maximal inhibitory concentration: 15.9 nM
Compound 3: middle estimate off by 1.6-fold (0.20 log units), on the low side; low and high end bracket the measured number.
By their numbers in this assay, from the lowest: compounds 1, 2 and 3 (each within the scatter of the next).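

In this assay, (2H-tetrazol-5-yl)methoxy in place of (1H-tetrazol-5-yl)methyl gives a 1.6-fold higher number from compound 2 to compound 3 (0.20 log units; within the scatter), and the same group in place of 2H-tetrazol-5-yl gives a 1.6-fold higher number from compound 1 to compound 3 (0.20 log units; within the scatter). The earlier pair covered only the directly attached group and its one-carbon (1H-tetrazol-5-yl)methyl counterpart; this result adds a group with an oxygen atom and more heavy atoms at the same place, on an aromatic carbon para to a large group, and all three listed forms stay within the scatter of one another in this read-out. No supporting data accompany these values to account for this outcome.

On these data alone, it remains open whether the read-out would stay within the scatter with a carboxylic acid or an amine at this place in place of the tetrazole-bearing groups, or with a longer chain carrying the tetrazole. The compounds shown also leave open whether this result holds with other groups in place of the propyl chain or the acetyl group on the shared core.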